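Thiosemicarbazone Replacement on a Second Core: Expected Antiproliferative Effect

The source may hold more compounds than are shown below. What is called first, only, known or untested is meant among the compounds shown, and "the series" means these compounds.

Measured compounds:
compound 1 `COc1ccccc1NC1=C/C(=N/NC(N)=S)C(=O)N=C1Nc1ccccc1OC` — 20800 nM
compound 2 `NC(=S)N/N=C1/C=C(Nc2ccc(F)cc2)C(Nc2ccc(F)cc2)=NC1=O` — 3720 nM
compound 3 `N/C(=N\N=C1\C=C(Nc2ccc(F)cc2)C(Nc2ccc(F)cc2)=NC1=O)SCc1ccccc1` — 11500 nM

In a functional assay on HCT-116 cells (Homo sapiens) for antiproliferative activity, read by MTT assay, with a stated time of 72 h (on this read-out lower numbers stand for stronger inhibition and higher numbers for weaker inhibition), compound 2 gives 3720 nM, while compound 3 `N/C(=N\N=C1\C=C(Nc2ccc(F)cc2)C(Nc2ccc(F)cc2)=NC1=O)SCc1ccccc1` gives 11500 nM; the change between them is a group of 11 heavy atoms (8 carbon, 2 nitrogen, 1 sulfur; one six-membered aromatic ring of carbon only) in place of a group of 4 heavy atoms (1 carbon, 2 nitrogen, 1 sulfur; no ring), on a double-bonded nitrogen, and it made a step of a 3.1-fold higher number from compound 2 to compound 3 (0.49 log units; beyond the scatter). Compound 1 `COc1ccccc1NC1=C/C(=N/NC(N)=S)C(=O)N=C1Nc1ccccc1OC` gives 20800 nM in this assay; how its core differs from that of compound 2 is not broken down here. Compound 4 `COc1ccccc1NC1=C/C(=N/N=C(\N)SCc2ccccc2)C(=O)N=C1Nc1ccccc1OC` has not yet been measured. It differs from compound 1 by a group of 11 heavy atoms (8 carbon, 2 nitrogen, 1 sulfur; one six-membered aromatic ring of carbon only) in place of a group of 4 heavy atoms (1 carbon, 2 nitrogen, 1 sulfur; no ring), on a double-bonded nitrogen, the same change as from compound 2 to compound 3. Because the step of a 3.1-fold higher number from compound 2 to compound 3 (0.49 log units; beyond the scatter) was modest, a step of similar size is expected for compound 4, namely a 2.9-fold higher number from compound 1 to compound 4 (0.46 log units; beyond the scatter). Compound 4 is therefore estimated at 60000 nM in this assay, between 20000 nM and 200000 nM.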

Compound 4, half-maximal inhibitory concentration: 14500 nM
Estimate against measurement, compound 4: 4.1-fold (0.62 log units) above; measured number below the stated range.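

In this assay, putting the larger group in place of the smaller one on the core of compound 1 gave a 1.4-fold lower number from compound 1 to compound 4 (0.16 log units; within the scatter), so on this core the change made no step beyond the scatter. Set beside the step on the other core, the two results do not agree: the same change on two cores in this assay, a 3.1-fold higher number (0.49 log units; beyond the scatter) from compound 2 to compound 3 and a 1.4-fold lower number (0.16 log units; within the scatter) from compound 1 to compound 4, 4.4-fold (0.65 log units) apart, beyond the scatter of two such steps

This shows that, in these two pairs, the step seen on one core did not carry over to the other, but it does not show which difference between the cores lies behind this or how the change would behave on any further core. The compounds shown leave open whether a methyl group or a longer alkyl chain in place of the aromatic ring of the entering group would split the two cores in the same way.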